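This account rests on a few compounds, and the source may have more. Where it says the series, first, only, none or still open, it means among the compounds named here.

Measured so far:
compound 1 `CCCCCc1ccc(-c2cc3cn([C@H]4C[C@H](O)[C@@H](COC(=O)[C@@H](NC(=O)[C@@H]5CCCN5C(=O)[C@@H](N)C(C)C)C(C)C)O4)c(=O)nc3o2)cc1` — > 95%
compound 2 `CCCCCc1ccc(-c2cc3cn([C@H]4C[C@H](OC(=O)[C@@H](NC(=O)[C@@H]5CCCN5C(=O)[C@@H](N)C(C)C)C(C)C)[C@@H](COC(=O)[C@@H](NC(=O)[C@@H]5CCCN5C(=O)[C@@H](N)C(C)C)C(C)C)O4)c(=O)nc3o2)cc1` — > 95%

In a physicochemical assay, read by HPLC, in phosphate buffer, with a stated time of 24 h, at pH 7.4 (a higher number here means that more of the compound is left, a lower number that less of the compound is left), compound 1 gives > 95%, which is a limit of the assay and not a number. Compound 2 also reaches a limit, > 95%, in this assay. Within the data shown here, every value so far sits at that limit (the limit of > 95% in this assay, at which 2 of the 2 values shown sit), so compound 1 stands where the whole set stands, with no number to rank it.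

Compound 3 `CCCCCc1ccc(-c2cc3cn([C@H]4C[C@H](O)[C@@H](COC(=O)[C@H](C)NC(=O)[C@@H]5CCCN5C(=O)[C@@H](N)C(C)C)O4)c(=O)nc3o2)cc1` differs from compound 1 by methyl in place of isopropyl on a saturated chain carbon bound to an amide-type nitrogen and a carbonyl carbon.

Among the measured compounds shown here, no step between measured compounds is available. In this assay no step beyond the scatter is expected from this change. Compound 3 is estimated at 97%, with a range from 90% to 100%. The expected step that the limit leaves unreadable from compound 1 to compound 3 is thus essentially none, most likely again reported only as a limit.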

Compound 3, percent of the compound remaining: 74%
Beside the measured number, compound 3's estimate is 23 percentage points above it; the measured number lies below the stated range.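

In this assay, methyl in place of isopropyl on a saturated chain carbon bound to an amide-type nitrogen and a carbonyl carbon gives a number at least 21 percentage points lower from compound 1 to compound 3 (beyond the scatter). This place therefore bears on how much compound is left, which the two earlier compounds could not show. The full size of the step cannot be read because compound 1 stands at a limit: the limit of > 95% in this assay, at which 2 of the 3 values shown sit.

Still open, from the compounds shown here alone, is whether ethyl or a longer chain at this carbon stays with compound 1 or falls with compound 3. These values also do not tell what compound 3 turns into.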